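This account rests on a few compounds, and the source may have more. Where it says the series, first, only, none or still open, it means among the compounds named here.

Compound 3 `CCCSc1nc2nc(C)cc(Nc3cc(-c4ccccc4)[nH]n3)n2n1` is the starting point in an ADME assay on GES1 cells (Homo sapiens) for inhibition, read by MTT assay, with a stated time of 72 h; a higher number here means a weaker inhibitor, a lower number a stronger inhibitor. In this assay compound 3 gives only a limit of the assay, > 50000 nM. Compound 1 `Cc1cc(Nc2cc(-c3ccccc3)[nH]n2)n2ncnc2n1` likewise reaches only a limit in this assay, > 50000 nM. Among the compounds with values here, compound 2 `Cc1cc(Nc2cc(-c3ccccc3)[nH]n2)n2nc(SCc3csc4ccccc34)nc2n1` in this assay gives 29200 nM, the single number among the three, so that the data show (the limit of > 50000 nM in this assay, at which 2 of the 3 values shown sit). The change to compound 4 `COc1ccc(CSc2nc3nc(C)cc(Nc4cc(-c5ccccc5)[nH]n4)n3n2)cc1` is 4-methoxyphenyl in place of ethyl on a saturated chain carbon bound to a sulfur. Within the data shown here, two measured steps bear on it. The step of an at least 1.7-fold higher number from compound 2 to compound 3 (0.23 log units; that floor lies within the scatter) runs the opposite way from the present change, putting ethyl where 1-benzothiophen-3-yl stood on the saturated chain carbon bound to a sulfur, and an at least 1.7-fold lower number from compound 1 to compound 2 (0.23 log units; that floor lies within the scatter) shows what the ((1-benzothiophen-3-yl)methyl)sulfanyl arm gave in place of hydrogen; both floors lie within the scatter. The return to an aromatic group in compound 4 is therefore expected to give a step of an at least 1.4-fold lower number from compound 3 to compound 4 (0.15 log units; that floor lies within the scatter) that stays within the scatter, with a real chance of another limit. Compound 4 is estimated at 35000 nM, with a range from 15000 nM to 80000 nM.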

Compound 4, half-maximal inhibitory concentration: 28200 nM
Compound 4: the middle estimate sits 1.2-fold (0.09 log units) above what was measured; measured number inside the range.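

In this assay, 4-methoxyphenyl in place of 1-benzothiophen-3-yl on the saturated chain carbon bound to a sulfur gives a 1.0-fold lower number from compound 2 to compound 4 (0.02 log units; within the scatter), so these two aromatic groups cannot be told apart at this place. Against ethyl the same change gives an at least 1.7-fold lower number from compound 3 to compound 4 (0.24 log units; that floor lies within the scatter), and the whole (4-methoxybenzyl)sulfanyl arm in place of hydrogen on an aromatic carbon gives an at least 1.7-fold lower number from compound 1 to compound 4 (0.24 log units; that floor lies within the scatter). Both of these steps start from a limit of the assay and are floors, so their true size remains unknown: the limit of > 50000 nM in this assay, at which 2 of the 4 values shown sit.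

The compounds shown leave open whether a longer chain in place of ethyl would give a number rather than a limit. They also leave open whether an amine or a carboxylic acid on the phenyl ring in place of methoxy would bring a step beyond the scatter.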